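This account rests on a few compounds, and the source may have more. Where it says the series, first, only, none or still open, it means among the compounds named here.

Compound 1 `COc1cc(/C=C/C(C)=O)ccc1OCc1cn(-c2ccc(NC(=O)c3ccccc3)cc2)nn1` gives 86700 nM in a functional assay on MCF7 cells (Homo sapiens) for antiproliferative activity, read by MTT assay, with a stated time of 48 h; on this read-out higher numbers stand for weaker inhibition and lower numbers for stronger inhibition.
Compound 2 `CCOC(=O)c1ccc(-n2cc(COc3ccc(/C=C/C(C)=O)cc3OC)nn2)cc1` gives > 100000 nM in this assay.

Compound 2 stands not at a number but at a limit of this assay; the entry for compound 2 is one of the values sitting at the limit of > 100000 nM in this assay, at which 1 of the 2 values shown sits. Compound 1 sits at a measured number, and both results describe weak inhibition of cell growth.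

Compound 3 `COc1cc(/C=C/C(C)=O)ccc1OCc1cn(-c2ccc(-c3ccccc3)cc2)nn1` differs from compound 2 by phenyl in place of ethoxycarbonyl on an aromatic carbon. Within the data shown here, the same position was changed in the one measured step, where benzamido gave way to ethoxycarbonyl; that step was an at least 1.1-fold higher number from compound 1 to compound 2 (0.06 log units; that floor lies within the scatter), so two quite different groups at this aromatic carbon left the weak activity essentially unchanged. Among the measured compounds shown here, this is the only step that bears on the exchange for phenyl, and it gives no sign of a strong movement in either direction; the expectation for compound 3 is therefore a change no larger than the scatter, with the added uncertainty that compound 2 is known only as a limit.

Compound 3 is thus expected at 90000 nM, within a range from 30000 nM to 250000 nM. The expected step is an at least 1.1-fold lower number from compound 2 to compound 3 (0.04 log units; that floor lies within the scatter).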

Compound 3, half-maximal inhibitory concentration: 65400 nM
For compound 3 the middle estimate is 1.4-fold (0.14 log units) above the measured one; the range from low to high includes it.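

Phenyl is a ring of carbon only, and here it takes the place of benzamido and of ethoxycarbonyl on an aromatic carbon, para to a large group; in this assay, replacing benzamido gives a 1.3-fold lower number from compound 1 to compound 3 (0.12 log units; within the scatter), so a third group with a quite different make-up leaves compound 3 indistinguishable from compound 1. Replacing ethoxycarbonyl, which has 2 hydrogen-bond acceptors, with phenyl, which has none, gives an at least 1.5-fold lower number from compound 2 to compound 3 (0.18 log units; that floor lies within the scatter), so even this exchange shows no difference that can be told from the usual spread of repeated measurements. Compound 2 stands at a limit of the assay, so the step to it has only a floor and its full size stays unknown: the limit of > 100000 nM in this assay, at which 1 of the 3 values shown sits.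

The compounds shown leave open whether any group at this carbon can move the result clearly beyond the scatter, since all three measured results describe weak inhibition of cell growth. Going by these compounds, what an amine, a carboxylic acid or a longer chain would do in this place remains unknown, and so does whether a change elsewhere on the shared core would matter more.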